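The source may report more compounds than this note shows. Statements on the series, on what has been measured and on what is new or still open speak of the compounds shown alone.

In an ADME assay on Huh-7 cells (Homo sapiens) for cytotoxicity (a higher number here means a weaker inhibitor, a lower number a stronger inhibitor), three compounds of one shared core have been measured. Compound 1, `CN(c1cc2ncc(=O)[nH]c2cc1NC(=S)NC(=O)c1ccc(OC(F)(F)F)cc1)C1CCCCC1`, gives 6470 nM. Compound 2, `CN(c1cc2ncc(=O)[nH]c2cc1NC(=N)NCc1cccc(C(F)(F)F)c1)C1CCCCC1`, gives 54000 nM. Compound 3, `CN(c1cc2ncc(=O)[nH]c2cc1Nc1nc(-c2ccccc2)cs1)C1CCCCC1`, gives 62500 nM, which is the highest of the three numbers; compound 2 sits within the scatter of compound 3, while compound 1 lies well below it, beyond the scatter, so compound 3 and compound 2 together stand apart from compound 1 in this assay.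

Compound 4, `CN(c1cc2ncc(=O)[nH]c2cc1Nc1nc(-c2cccc3ccccc23)cs1)C1CCCCC1`, is not yet measured. It differs from compound 3 in one place: naphthalen-1-yl in place of phenyl on an aromatic carbon. The shared core, the methyl-bearing nitrogen with its cyclohexyl group and the five-membered ring all stay as they are.

Within the data shown here, no step between two measured compounds carries this kind of change, so there is nothing here to set its size from. Compound 2 and compound 3 carry quite different groups at the same position and yet sit within the scatter of each other, which suggests that changes on that side of the molecule have so far moved this assay little. The number for compound 4 is therefore expected to stay close to that of compound 3, with the step from compound 3 to compound 4 estimated as a 1.3-fold lower number from compound 3 to compound 4 (0.10 log units; within the scatter), not clearly beyond the scatter in either direction. For compound 4 the estimate in this assay is 50000 nM, within a range from 20000 nM to 100000 nM.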

Compound 4, half-maximal inhibitory concentration: 57400 nM
The estimate for compound 4 lay 1.1-fold (0.06 log units) below the measured number; low and high end bracket the measured number.
By their numbers in this assay, from the lowest: compound 1; then compounds 2, 4 and 3 (each within the scatter of the next).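

In this assay, putting naphthalen-1-yl in place of phenyl on the aromatic carbon of the five-membered aromatic ring with 1 nitrogen and 1 sulfur gives a 1.1-fold lower number from compound 3 to compound 4 (0.04 log units; within the scatter). Among these compounds, this is the first direct reading of a single change at this position, and it shows that adding a second six-membered aromatic ring of carbon only leaves the number within the scatter, a result that holds for this one change alone. Nothing measured here bears on why the number stays where it does.

Both groups compared at this position are made of aromatic carbon only and carry no hydrogen-bond donors or acceptors, so the compounds shown leave open whether an amine or a carboxylic acid on the phenyl ring, or a methyl group or a longer alkyl chain in its place, would shift the number. They also leave open whether the same swap of phenyl for naphthalen-1-yl would read the same way if the cyclohexyl group on the methyl-bearing nitrogen gave way to another group.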